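Methoxy added to the aryl ketone arm: compound 4

The source may report more compounds than this note shows. Statements on the series, on what has been measured and on what is new or still open speak of the compounds shown alone.

Values in a functional assay on the whole organism (strain Swiss) with Mus musculus as the target, in the writhing test, with a stated time of 25 min, at a dose of 10 mg/kg by the oral route; a higher number here means more inhibition at the dose given (going by the name of the read-out), a lower number less inhibition:
compound 1, `O=C(Cc1ccccc1Nc1c(Cl)cccc1Cl)N/N=C/c1ccccc1O`, gives 60.5%
compound 2, `O=C(Cc1ccccc1Nc1c(Cl)cccc1Cl)N/N=C/c1ccc(Br)cc1`, gives 68.7%
compound 3, `COc1cccc(C(=O)CSc2nnc(Cc3ccccc3Nc3c(Cl)cccc3Cl)o2)c1`, gives 66.9%

Compound 3 holds the second highest of the three numbers; the values of compound 2 and of compound 1 both lie within the usual scatter of its own, so no order among the three can be read. Compound 4, `COc1ccc(C(=O)CSc2nnc(Cc3ccccc3Nc3c(Cl)cccc3Cl)o2)cc1OC`, is still to be measured in this assay. It differs from compound 3 by methoxy in place of hydrogen on an aromatic carbon.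

Among the measured compounds shown here, the only measured step, a number 8.2 percentage points higher from compound 1 to compound 2 (within the scatter), concerns a different arm of the molecule and is itself within the scatter. For the measured compounds named here, no measured step adds a methoxy, so nothing in the data points to a move in either direction for compound 4. The estimate for compound 4 therefore rests on the value of compound 3 alone, and the expected step is a number 1.9 percentage points lower from compound 3 to compound 4 (within the scatter), none beyond the scatter. Compound 4 is expected to give about 65%, with a range from 50% to 78%.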

Compound 4, a percentage reported as inhibition, in the whole organism at one dose (the size of the read-out at that dose, not a potency): 51.4%
Beside the measured number, compound 4's estimate is 13.6 percentage points above it; the measured number falls inside the stated range.
By their numbers in this assay, from the lowest: compounds 4, 1, 3 and 2 (each within the scatter of the next, the first and the last beyond it).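

In this assay, going from 3-methoxyphenyl to 3,4-dimethoxyphenyl on the aryl ketone arm gives a number 15.5 percentage points lower from compound 3 to compound 4 (beyond the scatter), the only step shown that lies beyond the scatter. This aromatic carbon, ortho to a methoxy group and para to a large group, is therefore not indifferent to substitution, and adding this small group is enough to lower the read-out at this dose. The data shown give no measured basis for explaining the step.

On these data alone, it remains open whether the drop is specific to methoxy or follows from any group at this carbon, which a hydroxy group, a chlorine atom or an amine in the same place would test. Also open, as far as these compounds go, is whether the step depends on the methoxy already on the ring, since this single pair cannot separate the two cases.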